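Working notes: ethyl to chloro on compound 2

This account rests on a few compounds, and the source may have more. Where it says the series, first, only, none or still open, it means among the compounds named here.

compound 1 `O=C(/C=C/c1cccnc1)NCCCCCCc1cccc(S(=O)(=O)Nc2ccccc2)c1`: 0.63 nM
compound 2 `CCc1ccc(NS(=O)(=O)c2cccc(CCCCCCNC(=O)/C=C/c3cccnc3)c2)cc1`: 3.64 nM

Among the measured compounds shown here, in a functional assay on MCF7 cells (Homo sapiens) for inhibition, read by CCK-8 assay, with a stated time of 72 h (on this read-out lower numbers stand for stronger inhibition and higher numbers for weaker inhibition), compound 2 gives 3.64 nM as the highest of the two numbers so far, and compound 1 sits lower. The next structure is compound 3 `O=C(/C=C/c1cccnc1)NCCCCCCc1cccc(S(=O)(=O)Nc2ccc(Cl)cc2)c1` and the difference from compound 2 is as follows: chloro in place of ethyl on an aromatic carbon. For the measured compounds named here, only one measured step bears on this change. Ethyl in place of hydrogen on an aromatic carbon gave a 5.8-fold higher number from compound 1 to compound 2 (0.76 log units; beyond the scatter) as a modest step beyond the scatter. Going by the values given here, compound 3 gives up that ethyl, so part of that step may be recovered, but no measured compound carries chloro and its own contribution is unknown. A move toward a lower number is therefore expected, smaller than the measured step. The expected step is a 2.3-fold lower number from compound 2 to compound 3 (0.36 log units; beyond the scatter) in this assay with wide uncertainty. For compound 3 the estimated value is 1.6 nM with an expected range (from 0.5 nM to 5 nM).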

Compound 3, half-maximal inhibitory concentration: 5.94 nM
Beside the measured number, compound 3's estimate is 3.7-fold (0.57 log units) below it; measured number above the stated range.
By their numbers in this assay, from the lowest: compound 1; then compounds 2 and 3 (each within the scatter of the next).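

In this assay the exchange of ethyl for chloro at this position reads a 1.6-fold higher number from compound 2 to compound 3 (0.21 log units; within the scatter), so the two groups cannot be told apart on this read-out. Chloro in place of hydrogen reads a 9.4-fold higher number from compound 1 to compound 3 (0.97 log units; beyond the scatter) and ethyl in place of hydrogen reads a 5.8-fold higher number from compound 1 to compound 2 (0.76 log units; beyond the scatter), so the step away from compound 1 is not confined to ethyl: both groups, on the aromatic carbon para to a large group, give numbers beyond the scatter from the unsubstituted compound, and neither compound goes against this within the three shown. No measured evidence on hand says why the two groups read alike here.

The compounds shown leave open whether any group at this place keeps the low number of compound 1, for example fluoro, methoxy, an amine or a carboxylic acid, or whether every replacement of that hydrogen costs a similar step. Also open, going by these compounds, is whether a longer chain at this place would go further than ethyl, and whether any read-out other than this assay would order these compounds the same way.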